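Phenyl Added at the Selenium-Bound Carbon of Compound 3

The compounds below may be only part of what the source reports. "The series", "measured", "known", "first", "only" and "open" are said of these compounds alone.

Three selenium-bearing bis-amides were run through an ADME assay on MCF-10A cells (Homo sapiens) for cytotoxicity, read by MTT assay, with a stated time of 72 h; on this read-out lower numbers stand for stronger inhibition of growth and higher numbers for weaker inhibition of growth. Compound 1 `C[Se]/C(=N\C(=O)c1ccco1)NC(=O)c1ccco1` gives 5940 nM in this assay, and compound 2 `C[Se]/C(=N\C(=O)c1sccc1Cl)NC(=O)c1sccc1Cl` gives 3160 nM. Compound 3 `C[Se]/C(=N\C(=O)c1cnc2ccccc2c1)NC(=O)c1cnc2ccccc2c1` stands at the top of these three numbers with 20300 nM in this assay; its nearest neighbour is compound 1, whose number is lower by a margin beyond the scatter, and compound 2 lies further away still, also beyond the scatter. Compound 3 is therefore the weakest inhibitor of growth of the three measured.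

Compound 4 `O=C(/N=C(/NC(=O)c1cnc2ccccc2c1)[Se]Cc1ccccc1)c1cnc2ccccc2c1` keeps the whole of compound 3 apart from a single change: phenyl in place of hydrogen on a saturated chain carbon bound to a selenium atom. Among the measured compounds shown here, no measured pair shows this exact change, so its effect on this assay is not known from the data here. Compound 3 is nevertheless a sensible anchor, and the account that follows treats the change as likely to pull the number down somewhat rather than up. For compound 4 the step of a 2.5-fold lower number from compound 3 to compound 4 (0.40 log units; beyond the scatter) is expected to be a modest one toward a lower number in this assay. Compound 4 is accordingly estimated at 8000 nM in this assay, within a range from 3000 nM to 25000 nM.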

Compound 4, concentration for 50% growth inhibition: 23600 nM
The estimate for compound 4 lay 3.0-fold (0.47 log units) below the measured number; the range from low to high includes it.
By their numbers in this assay, from the lowest: compounds 2 and 1 (each within the scatter of the next); then compounds 3 and 4 (each within the scatter of the next).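

In this assay the swap of phenyl in place of hydrogen on a saturated chain carbon bound to a selenium atom gives a 1.2-fold higher number from compound 3 to compound 4 (0.07 log units; within the scatter) and so, read the other way, methyl to benzyl at this place leaves the number where the scatter cannot separate the two compounds. Among the compounds shown here, the earlier compounds offered no step between compounds differing in one place, so this is the first reading of any single change, and it shows that this place accepts a whole six-membered aromatic ring of carbon only with no change this read-out can detect, at least on the core shared by compound 3 and compound 4. Nothing available here explains this flat result.

From the compounds shown here alone, a single aromatic ring is only one probe, so it remains open whether an amine, a carboxylic acid or a longer chain such as phenethyl at the same place would also leave the number undisturbed. Going by these compounds, it is equally open whether methyl to benzyl would read the same on the core of compound 1 or the core of compound 2, whose numbers lie well apart from that of compound 3.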